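Lipophilicity of a quinoline amide series, extended by one analogue

The source may report more compounds than this note shows. Statements on the series, on what has been measured and on what is new or still open speak of the compounds shown alone.

Of the compounds shown here, three have been measured in a physicochemical assay for lipophilicity, read by HPLC, in phosphate buffer, measured as chromatographic lipophilicity, at pH 7.4; on this read-out lower numbers stand for lower lipophilicity and higher numbers for higher lipophilicity. Compound 1 `Cc1cc(C)cc(NC(=O)COc2cc(C)nc3ccccc23)c1` gives 5.39, compound 2 `COc1ccc2nc(C)cc(NCC(=O)Nc3cc(C)cc(C)c3)c2c1` gives 3.59, and compound 3 `COc1ccc2nc(C)cc(OCC(=O)Nc3cccc(C)c3)c2c1` gives 4.83. Compound 3 therefore stands second highest of the three: compound 1 lies higher by a margin beyond the scatter, and compound 2 lies lower by a larger margin, also beyond the scatter. The new analogue, compound 4 `COc1ccc2nc(C)cc(OCC(=O)Nc3cc(C)c(F)c(C)c3)c2c1`, differs from compound 3 in one place: 4-fluoro-3,5-dimethylphenyl in place of 3-methylphenyl on an amide-type nitrogen. Among the measured compounds shown here, no step of this kind between measured compounds is available, so the expected change rests on the structural change alone. The expected step is a number 0.67 log units higher from compound 3 to compound 4 (beyond the scatter), upward and beyond the scatter. In this assay compound 4 is estimated at 5.5, within a range from 5 to 6.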

Compound 4, distribution coefficient: 5.5
Beside the measured number, compound 4's estimate shows no gap at the digits printed; the range from low to high includes it.
By their numbers in this assay, from the lowest: compound 2; then compound 3; then compounds 1 and 4 (each within the scatter of the next).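

In this assay, among the compounds shown here, the change from 3-methylphenyl to 4-fluoro-3,5-dimethylphenyl on the amide-type nitrogen gives the only step read at this position: a number 0.67 log units higher from compound 3 to compound 4 (beyond the scatter), modest but beyond the scatter. The position therefore responds to a change of this group, here one of 9 heavy atoms replacing one of 7. No measurement at hand gives a cause for this rise.

The compounds shown do not separate the share of the fluorine from that of the added methyl. On these data alone, how an amine or a carboxylic acid on this phenyl ring would read also remains open.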